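The source may hold more compounds than are shown below. What is called first, only, known or untested is meant among the compounds shown, and "the series" means these compounds.

In a toxicity assay on MT4 cells (Homo sapiens) for cytotoxicity, read by MTT assay (a lower number here means that less compound is tolerated, a higher number that more compound is tolerated), compound 1 `COc1cc(Oc2cc(N)nc(Nc3ccc(C#N)cc3)n2)ccc1-c1ccc(C#N)cc1` gives 12900 nM and compound 2 `Cc1cc(-c2ccccc2Cl)cc(C)c1Oc1cc(N)nc(Nc2ccc(C#N)cc2)n1` gives 25100 nM. For the measured compounds named here, these two values lie within the usual scatter of each other, so compound 2 stands level with the only other measured number. Compound 3 `COc1ccc(-c2cc(C)c(Oc3cc(N)nc(Nc4ccc(C#N)cc4)n3)c(C)c2)cc1` carries 4-methoxyphenyl in place of 2-chlorophenyl on an aromatic carbon. Going by the values given here, the data hold no step between measured compounds that differ in one place, so no shift beyond the scatter is expected in this assay. The estimated change is a 1.4-fold lower number from compound 2 to compound 3 (0.14 log units; within the scatter). Compound 3 is expected at 18000 nM, within an estimated range of 6000 nM to 50000 nM.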

Compound 3, half-maximal cytotoxic concentration: 10700 nM
The estimate for compound 3 lay 1.7-fold (0.23 log units) above the measured number, within the range that was stated.
By their numbers in this assay, from the lowest: compounds 3, 1 and 2 (each within the scatter of the next, the first and the last beyond it).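

In this assay, for the compounds shown here, 4-methoxyphenyl in place of 2-chlorophenyl on this aromatic carbon gives a 2.3-fold lower number from compound 2 to compound 3 (0.37 log units; beyond the scatter), the only step so far, and a modest one. The position is therefore not silent to an exchange of one aryl group for another: the number moves beyond the scatter, towards less compound tolerated. Nothing available bears on why the number shifts.

Still open, from the compounds shown here alone, is whether the shift goes with the chlorine leaving or the methoxy entering. Also open, going by these compounds, is how an unsubstituted phenyl or a morpholine on this carbon would read.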